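The source may hold more compounds than are shown below. What is called first, only, known or untested is meant among the compounds shown, and "the series" means these compounds.

Measured so far: compound 1 `CCOC(=O)CCC(=O)N1CCN(CCCOc2cc3c(Nc4ccc(F)c(Cl)c4)ncnc3cc2OC)CC1`, 61.6% in a functional assay on A549 cells (Homo sapiens) for cytotoxicity, read by MTT assay, with a stated time of 24 h, tested at 60 uM; a higher number here means a weaker effect of the compound at the concentration tested, a lower number a stronger effect; compound 2 `CCCCCCCCCCOC(=O)CCC(=O)N1CCN(CCCOc2cc3c(Nc4ccc(F)c(Cl)c4)ncnc3cc2OC)CC1`, 3.9%; compound 3 `CCCCCCCCCCCCCOC(=O)CCC(=O)N1CCN(CCCOc2cc3c(Nc4ccc(F)c(Cl)c4)ncnc3cc2OC)CC1`, 20.6%.

Compound 3 stands second highest of the three, above compound 2 and well below compound 1. Compound 4 `CCCCCCCCCCCCCCCCCCCOC(=O)CCC(=O)N1CCN(CCCOc2cc3c(Nc4ccc(F)c(Cl)c4)ncnc3cc2OC)CC1` differs from it by hexyl in place of hydrogen on a saturated chain carbon, ten or more bonds along the chain from an oxygen next to a carbonyl group. Within the data shown here, the one step at that same place is a number 16.7 percentage points higher from compound 2 to compound 3 (beyond the scatter), a modest rise; the large falls a number 57.7 percentage points lower from compound 1 to compound 2 (beyond the scatter) and a number 41 percentage points lower from compound 1 to compound 3 (beyond the scatter) sit two bonds from the oxygen and bear only indirectly. Lengthening the chain further is therefore expected to move the number up again, by about a number 17.4 percentage points higher from compound 3 to compound 4 (beyond the scatter). Compound 4 is estimated at 38%, between 15% and 65%.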

Compound 4, a percentage reported as activity, at one concentration (the size of the read-out at that concentration, not a potency): 89.3%
For compound 4 the middle estimate is 51.3 percentage points below the measured one; the whole stated range lies below it.
By their numbers in this assay, from the lowest: compound 2; then compound 3; then compound 1; then compound 4.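

In this assay, hexyl in place of hydrogen at this far stretch of the chain gives a much larger step than the earlier one at that place, a number 68.7 percentage points higher from compound 3 to compound 4 (beyond the scatter), and across the whole stretch the step is a number 85.4 percentage points higher from compound 2 to compound 4 (beyond the scatter). Compound 4 has the highest of the four numbers, so the number does not follow chain length in one direction: the fall from compound 1 to compound 2 goes against the later rises. Nothing given here accounts for this turn.

Open, as far as these compounds go, is how the number behaves for chains intermediate between those of compound 3 and compound 4. Also open, from the compounds shown here alone, is whether a carboxylic acid or an amine at the chain end would alter the trend.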